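A few compounds are considered here, and "the series" means these few. Any claim that something is new, unique, unknown or untested is made for them only; others in the source may bear on it.

Measured compounds in a functional assay on WiDr cells (Homo sapiens) for inhibition, read by sulforhodamine B assay, with a stated time of 48 h; on this read-out higher numbers stand for weaker inhibition of growth and lower numbers for stronger inhibition of growth:

compound 1, `COC(=O)[C@@]1(C)CCC=C2[C@@H]1CC[C@@H](C)[C@]2(C)Cc1c[nH]c2ccc(C)cc12`, 22000 nM
compound 2, `COC(=O)[C@@]1(C)CCC=C2[C@@H]1CC[C@@H](C)[C@]2(C)Cc1c[nH]c2c(Cl)cccc12`, 31000 nM
compound 3, `COC(=O)[C@@]1(C)CC[C@@H]2C3=C1CC[C@@H](C)[C@]3(C)C[C@@H]1c3ccccc3N[C@H]21`, 50000 nM

Compound 3 carries the highest number of the three in this assay. Its nearest neighbour on the numbers is compound 2, whose value lies within the scatter of compound 3, so the two are not told apart. Compound 1 lies beyond the scatter, with a lower number than compound 3, so compound 1 inhibits growth more strongly than compound 3. Going by the values given here, all three values sit in the high range of this assay, and none of the pairs differs in one place only, so no step between measured compounds can be read off.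

Compound 4, `COC(=O)[C@@]1(C)CC[C@@H]2C3=C1CC[C@@H](C)[C@]3(C)C[C@@H]1c3cc(OC)ccc3N[C@H]21`, differs from compound 3 in one place: methoxy in place of hydrogen on an aromatic carbon. Among the compounds with values here, no measured pair shows what such a change does on this core in this assay. With nothing to go on beyond the spread of the three numbers, the change from compound 3 to compound 4 is expected to stay within the scatter, in no firm direction, which is the step of a 1.1-fold lower number from compound 3 to compound 4 (0.05 log units; within the scatter). Compound 4 is therefore expected at about 45000 nM in this assay, within the range 15000 nM to 120000 nM.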

Compound 4, concentration for 50% growth inhibition: 25000 nM
Compound 4: the middle estimate sits 1.8-fold (0.26 log units) above what was measured, within the range that was stated.
By their numbers in this assay, from the lowest: compounds 1, 4, 2 and 3 (each within the scatter of the next, the first and the last beyond it).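

Going by these compounds alone, compound 4 and compound 3 form the first pair that differs in one place only, which gives a direct reading of this aromatic carbon on the shared core. Methoxy in place of hydrogen, at the carbon meta to a fused ring and para to a fused ring, gives a 2.0-fold lower number from compound 3 to compound 4 (0.30 log units; within the scatter) in this assay, so the two compounds are not told apart, and this one pair shows that the position can carry methoxy without a change in growth inhibition beyond the scatter. No supporting measurement is available to explain the size of this step.

A single substituent at a single carbon says nothing yet about whether a different kind of group here, such as an amine, a carboxylic acid or a longer chain such as butoxy, would move the number in this assay beyond the scatter. On these data alone, it also remains open whether methoxy on the other aromatic carbons of the shared core would behave as it does at this one.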